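The source may hold more compounds than are shown below. What is called first, only, known or untested is meant among the compounds shown, and "the series" means these compounds.

Measured so far:
- compound 1, `S=c1[nH]nc(Cc2ccc(Cl)cc2Oc2ccccc2Cl)[nH]1`: 124%
- compound 2, `CCSc1nnc(Cc2ccccc2Oc2ccccc2)[nH]1`: 132%
- compound 3, `c1ccc(CSc2nnc(Cc3ccccc3Oc3ccccc3)[nH]2)cc1`: 129%

In a functional assay on the whole organism (strain NMRI) with Mus musculus as the target, with a stated time of 60 min, at a dose of 5 mg/kg by the intraperitoneal route (a higher number here means a stronger effect of the compound at the dose given, a lower number a weaker effect), compound 1 gives 124%, and its gaps to compound 2 and compound 3 both fall inside the usual scatter of this kind of measurement, so the three numbers cannot be told apart.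

Compound 4, `CSc1nnc(Cc2ccc(Cl)cc2Oc2ccccc2Cl)[nH]1`, is compound 1 with the change (a group of 7 heavy atoms (3 carbon, 3 nitrogen, 1 sulfur; one five-membered aromatic ring with 3 hetero atoms) in place of a group of 6 heavy atoms (2 carbon, 3 nitrogen, 1 sulfur; one five-membered aromatic ring with 3 hetero atoms), on a saturated chain carbon bound to an aromatic carbon). The sulfur-bearing ring is thus exchanged for a closely related one that carries a methyl on its sulfur. Among the measured compounds shown here, no measured pair shows exactly this exchange. For the measured compounds named here, the only step on record that touches the group on the sulfur is a number 3 percentage points lower from compound 2 to compound 3 (within the scatter), which was within the scatter; compound 2 and compound 3 each carry a substituted sulfur of this sort and give numbers no different from compound 1.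

On that basis no step beyond the scatter is expected for a number 4 percentage points higher from compound 1 to compound 4 (within the scatter) in this assay. Compound 4 is therefore estimated at 128%, with a likely range from 108% to 148%.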

Compound 4, a percentage reported as activity, at one dose (the size of the read-out at that dose, not a potency): 125%
Compound 4: middle estimate off by 3 percentage points, on the high side; measured number inside the range.
By their numbers in this assay, from the lowest: compounds 1, 4, 3 and 2 (each within the scatter of the next).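

In this assay, among the compounds shown here, the exchange on a saturated chain carbon bound to an aromatic carbon gives a number 1 percentage points higher from compound 1 to compound 4 (within the scatter), the first step on record that concerns the sulfur-bearing ring itself. At this place in the shared core, the group with 1 double bond outside aromatic rings and 2 hydrogen-bond donors and the group with 1 hydrogen-bond donor and a methyl on its sulfur therefore give numbers that cannot be told apart at the dose used. Nothing measured here offers an explanation for this result.

Going by these compounds, whether an amine or a carboxylic acid in place of that methyl would move the number beyond the scatter remains open. The contribution of the two chlorine atoms also remains open, as no pair shown differs in them alone.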